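Swapping Tellurium for Selenium in Compound 2

The source may report more compounds than this note shows. Statements on the series, on what has been measured and on what is new or still open speak of the compounds shown alone.

compound 1 `CCCC[Se]c1ccc(C(C)N)cc1`: > 100 ug/mL
compound 2 `CCCC[Te]c1ccc(C(C)NCC(C)C)cc1`: 12.5 ug/mL
compound 3 `C=CCNC(C)c1ccc([Te]CCCC)cc1`: > 100 ug/mL

Among the measured compounds shown here, in a functional assay, read by spectrophotometry, with a stated time of 30 min (on this read-out lower numbers stand for stronger inhibition and higher numbers for weaker inhibition), compound 2 gives 12.5 ug/mL, the only actual number among the three measured compounds. Compound 1 reaches only a limit of the assay, > 100 ug/mL. Compound 3 likewise stops at a limit, > 100 ug/mL. Compound 4, `CCCC[Se]c1ccc(C(C)NCC(C)C)cc1`, has not yet been measured. It differs from compound 2 by a group of 5 heavy atoms (4 carbon, 1 selenium; no ring) in place of a group of 5 heavy atoms (4 carbon, 1 tellurium; no ring), on an aromatic carbon. For the measured compounds named here, no measured step isolates this exchange: compound 1 also carries selenium, but with a bare amine, so compound 1 and compound 2 differ in two places at once. Going by the values given here, the one measured step, an at least 8.0-fold higher number from compound 2 to compound 3 (0.90 log units; beyond the scatter), concerns the amine substituent and shows how readily a change away from compound 2 pushes the read-out to the limit, as the limit of > 100 ug/mL in this assay, at which 2 of the 3 values shown sit, records. The expectation is therefore a weaker result for compound 4, a step of a 3.2-fold higher number from compound 2 to compound 4 (0.51 log units; beyond the scatter), with a real chance of only a limit. Compound 4 is estimated at 40 ug/mL, within the range 10 ug/mL to 150 ug/mL.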

Compound 4, half-maximal inhibitory concentration: > 100 ug/mL
Compound 4: no number, only a limit; the forecaster's own chance of this, stated with the estimate: 45%; at least 2.5-fold (0.39 log units) between middle value and limit.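

In this assay, the exchange of tellurium for selenium now has a step of its own, with the isobutyl on the amine nitrogen left unchanged: an at least 8.0-fold higher number from compound 2 to compound 4 (0.90 log units; beyond the scatter). The earlier compounds shown here could not show this, since compound 1 differs from compound 2 in two places at once, and the step between compound 1 and compound 4 cannot be read, as both values are limits. Among the compounds shown, only compound 2, which pairs tellurium with isobutyl, gives an actual number, and changing either of the two places loses it: the limit of > 100 ug/mL in this assay, at which 3 of the 4 values shown sit.

On these data alone, how far past the limit compound 4 truly lies remains unknown, so the full size of its step stays open. Also open, as far as these compounds go, is whether a butyl chain on sulfur, or a longer chain on tellurium, would give a measurable number.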